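Chloro in Place of Bromo on the Phenyl Ring

A few compounds are considered here, and "the series" means these few. Any claim that something is new, unique, unknown or untested is made for them only; others in the source may bear on it.

Three compounds have been measured in a functional assay on A549 cells (Homo sapiens) for antiproliferative activity, read by MTT assay, with a stated time of 72 h; on this read-out lower numbers stand for stronger inhibition and higher numbers for weaker inhibition:
compound 1 `COc1cc2ncnc(Nc3ccc(F)c(Cl)c3)c2cc1OCCCCC(=O)Nc1ccc(S(N)(=O)=O)cc1` gives 15500 nM;
compound 2 `C#Cc1cccc(Nc2ncnc3cc(OC)c(OCCCCC(=O)Nc4ccc(S(N)(=O)=O)cc4)cc23)c1` gives 7720 nM;
compound 3 `COc1cc2ncnc(Nc3cccc(Br)c3)c2cc1OCCCCC(=O)Nc1ccc(S(N)(=O)=O)cc1` gives 14900 nM.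

Compound 3 stands second highest of the three, and every step to it falls within the scatter: a 1.0-fold lower number from compound 1 to compound 3 (0.02 log units; within the scatter) and a 1.9-fold higher number from compound 2 to compound 3 (0.29 log units; within the scatter). Compound 4 `COc1cc2ncnc(Nc3cccc(Cl)c3)c2cc1OCCCCC(=O)Nc1ccc(S(N)(=O)=O)cc1` differs from compound 3 by chloro in place of bromo on an aromatic carbon. Among the measured compounds shown here, two measured steps bear on this: the exchange of halogen-bearing phenyl groups, a 1.0-fold lower number from compound 1 to compound 3 (0.02 log units; within the scatter), and the exchange of a single group on the same aromatic carbon, a 1.9-fold higher number from compound 2 to compound 3 (0.29 log units; within the scatter), both within the scatter. Compound 4 is therefore expected to show no step beyond the scatter in this assay, namely a 1.1-fold lower number from compound 3 to compound 4 (0.03 log units; within the scatter). Compound 4 is estimated at 14000 nM, between 6000 nM and 32000 nM.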

Compound 4, half-maximal inhibitory concentration: 11200 nM
Compound 4: the middle estimate sits 1.3-fold (0.10 log units) above what was measured; the range from low to high includes it.
By their numbers in this assay, from the lowest: compounds 2, 4, 3 and 1 (each within the scatter of the next).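

In this assay, chloro in place of bromo on this aromatic carbon (a 1.3-fold lower number from compound 3 to compound 4 (0.12 log units; within the scatter)) adds a second halogen that cannot be told from the first. Chloro in place of ethynyl (a 1.5-fold higher number from compound 2 to compound 4 (0.16 log units; within the scatter)) and hydrogen in place of fluoro (a 1.4-fold lower number from compound 1 to compound 4 (0.14 log units; within the scatter)) also stay within the scatter, so no change among these four compounds separates any of them. Nothing given here accounts for these small steps.

The compounds shown leave open whether an amine, a methoxy group or a nitrile on this aromatic carbon would give a step beyond the scatter.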